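Swapping Isopropyl for 4-Chlorophenyl on the Ring Nitrogen

The compounds below may be only part of what the source reports. "The series", "measured", "known", "first", "only" and "open" are said of these compounds alone.

Compound 3 `CC(C)N1C(=O)COc2ccc(-c3cccc(NS(=O)(=O)c4ccc(F)cc4)c3)cc21` is one of three analogues sharing one core and differing only in the group on an amide-type nitrogen in a ring. In a functional assay on A549 cells (Homo sapiens) for antiproliferative activity, read by MTT assay, with a stated time of 72 h (on this read-out lower numbers stand for stronger inhibition and higher numbers for weaker inhibition), compound 3 gives 29400 nM. Compound 1 `O=C1COc2ccc(-c3cccc(NS(=O)(=O)c4ccc(F)cc4)c3)cc2N1`, carrying hydrogen there, gives 32100 nM in this assay; the two numbers sit within the usual scatter of each other, with a 1.1-fold lower number from compound 1 to compound 3 (0.04 log units; within the scatter). Compound 2 `COc1cccc(N2C(=O)COc3ccc(-c4cccc(NS(=O)(=O)c5ccc(F)cc5)c4)cc32)c1` carries 3-methoxyphenyl and in this assay reaches only a limit, > 40000 nM. From that follow an at least 1.2-fold higher number from compound 1 to compound 2 (0.09 log units; that floor lies within the scatter) and an at least 1.3-fold lower number from compound 2 to compound 3 (0.13 log units; that floor lies within the scatter), so no step beyond the scatter has yet been seen. Compound 4 `O=C1COc2ccc(-c3cccc(NS(=O)(=O)c4ccc(F)cc4)c3)cc2N1c1ccc(Cl)cc1` brings (4-chlorophenyl in place of isopropyl on an amide-type nitrogen in a ring). Because compound 2 with its 3-methoxyphenyl reached the limit (the limit of > 40000 nM in this assay, at which 1 of the 3 values shown sits), a move toward weaker inhibition is expected for compound 4, a 1.4-fold higher number from compound 3 to compound 4 (0.13 log units; within the scatter). Compound 4 is estimated at 40000 nM in this assay, between 25000 nM and 80000 nM.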

Compound 4, half-maximal inhibitory concentration: 31600 nM
Compound 4: middle estimate off by 1.3-fold (0.10 log units), on the high side; measured number inside the range.
By their numbers in this assay, from the lowest: compounds 3, 4 and 1 (each within the scatter of the next). At a limit, above all of these: compound 2.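

In this assay, an aromatic ring on this ring nitrogen gives a measured number rather than a limit: 4-chlorophenyl shows no real difference from isopropyl (a 1.1-fold higher number from compound 3 to compound 4 (0.03 log units; within the scatter)) or from hydrogen (a 1.0-fold lower number from compound 1 to compound 4 (0.01 log units; within the scatter)). Hydrogen, isopropyl and 4-chlorophenyl therefore all sit within the scatter of one another at this position. Against compound 2, whose value is a limit, only a floor is available (an at least 1.2-fold lower number from compound 2 to compound 4 (0.10 log units; that floor lies within the scatter)), so the two aromatic groups cannot be ranked.

Still open, from the compounds shown here alone, is whether an amine or a carboxylic acid on this nitrogen would move the number beyond the scatter.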